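Chlorine position on the benzyl group: compound 1 to compound 4

This account rests on a few compounds, and the source may have more. Where it says the series, first, only, none or still open, it means among the compounds named here.

Three compounds have numbers in a functional assay on MGC-803 cells (Homo sapiens) for antiproliferative activity, read by MTT assay, with a stated time of 72 h; a lower number here means a stronger inhibitor, a higher number a weaker inhibitor. Compound 1 `CCCSc1nc(N/N=C(\C)c2ccccc2O)c2nnn(Cc3ccc(Cl)cc3)c2n1` gives 7100 nM. Compound 3 `CCCSc1nc(N/N=C/c2c[nH]c3ccccc23)c2nnn(Cc3ccccc3)c2n1` gives 7410 nM; these two values lie within the scatter of each other, so no order between compound 1 and compound 3 can be read from them. Compound 2 `CCCSc1nc(N/N=C(\C)c2ccc(O)cc2)c2nnn(Cc3ccccc3)c2n1` gives 16700 nM, a higher number than that of compound 1 by a margin beyond the scatter. Compound 1 thus holds the lowest number of the three, with compound 3 nearest and compound 2 furthest.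

Compound 4 `CCCSc1nc(N/N=C(\C)c2ccccc2O)c2nnn(Cc3cccc(Cl)c3)c2n1` has not yet been measured. It differs from compound 1 in one place: 3-chlorophenyl in place of 4-chlorophenyl on a saturated chain carbon bound to an aromatic nitrogen. Both compounds contain the same atoms, joined differently. Going by the values given here, no pair of measured compounds differs only in this way, so the step has no precedent and its size must be guessed. The step from compound 1 to compound 4, a 1.1-fold higher number from compound 1 to compound 4 (0.02 log units; within the scatter), is expected to fall within the scatter, with no direction favoured, since the rest of the molecule is unchanged. Compound 4 is therefore estimated at 7500 nM, with a range from 3500 nM to 16000 nM.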

Compound 4, half-maximal inhibitory concentration: 6500 nM
Compound 4: middle estimate off by 1.2-fold (0.06 log units), on the high side, within the range that was stated.
By their numbers in this assay, from the lowest: compounds 4, 1 and 3 (each within the scatter of the next); then compound 2.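

Moving the chlorine on the benzyl group gives the first comparison in the series that differs in one place: in this assay, 3-chlorophenyl in place of 4-chlorophenyl on a saturated chain carbon bound to an aromatic nitrogen gives a 1.1-fold lower number from compound 1 to compound 4 (0.04 log units; within the scatter). The 4-chlorobenzyl and 3-chlorobenzyl compounds therefore cannot be put in order, and this assay does not separate these two placements of the chlorine on the otherwise unchanged molecule. No independent measurement bears on this result.

As far as these compounds go, whether the chlorine itself contributes stays open: compound 2 and compound 3 carry an unsubstituted benzyl group, but they also differ from compound 1 elsewhere, so they give no reading of it. Also open, from the compounds shown here alone, is whether a different group on the benzyl ring at this place, such as a methoxy group, a dimethylamino group or a carboxylic acid, would move the number beyond the scatter, as the two chlorine placements here do not.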